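Cyano out, isobutyl in: a clearance forecast

The source may report more compounds than this note shows. Statements on the series, on what has been measured and on what is new or still open speak of the compounds shown alone.

Of the compounds shown here, three sharing one core have been measured in an ADME assay (liver) for metabolic stability, with Liver microsome (Homo sapiens) as the target, read by LC-MS, using microsomes and NADPH, with a stated time of 5 min, at 37 degrees C; a lower number here means slower removal, a higher number faster removal of the compound. Compound 1 `CCn1c([C@@H](C)NS(=O)(=O)C2CC2)nc2ccc(C(F)(F)F)cc21`, with cyclopropyl on the sulfonyl sulfur, reads < 3 mL.min-1.g-1, which is a limit of the assay and not a number. Compound 2 `CCn1c([C@@H](C)NS(=O)(=O)c2ccccc2)nc2ccc(C(F)(F)F)cc21` gives 14 mL.min-1.g-1. Compound 3 `CCn1c([C@@H](C)NS(=O)(=O)c2ccc(C#N)cc2)nc2ccc(C(F)(F)F)cc21` gives 34 mL.min-1.g-1, the highest number of the three and so the fastest removal.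

Compound 4 `CCn1c([C@@H](C)NS(=O)(=O)c2ccc(CC(C)C)cc2)nc2ccc(C(F)(F)F)cc21` has isobutyl in place of cyano on an aromatic carbon. Phenyl in place of cyclopropyl gave an at least 4.6-fold higher number from compound 1 to compound 2 (0.66 log units; beyond the scatter), and 4-cyanophenyl in its place gave an at least 11-fold higher number from compound 1 to compound 3 (1.05 log units; beyond the scatter). Within the data shown here, the closest guide is the one measured change on the carbon now altered, cyano in place of hydrogen, which gave a 2.4-fold higher number from compound 2 to compound 3 (0.39 log units; beyond the scatter), a modest rise. Among the measured compounds shown here, no measured compound carries isobutyl, so this forecast is loose. On that single guide, a further modest rise is expected in this assay, with the expected step of a 2.2-fold higher number from compound 3 to compound 4 (0.34 log units; beyond the scatter). For compound 4 the estimated value is 75 mL.min-1.g-1, with an expected range of 30 mL.min-1.g-1 to 180 mL.min-1.g-1.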

Compound 4, intrinsic clearance in microsomes: > 100 mL.min-1.g-1
Compound 4 gave a limit, no number; the forecaster's own chance of this, stated with the estimate: 10%; at least 1.3-fold (0.12 log units) between middle value and limit.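

In this assay compound 4 stands at a limit and gives no number: the limit of > 100 mL.min-1.g-1 in this assay, at which 1 of the 4 values shown sits.

Even so, isobutyl on this aromatic carbon gives an at least 7.1-fold higher number from compound 2 to compound 4 (0.85 log units; beyond the scatter), so a second group here, one made of carbon only, also raises the number over hydrogen, and its step from cyano, an at least 2.9-fold higher number from compound 3 to compound 4 (0.46 log units; beyond the scatter), shows that the choice of group matters and not merely the presence of one. Across the whole sulfonyl substituent the range now spans an at least 33-fold higher number from compound 1 to compound 4 (1.52 log units; beyond the scatter), a span with a limit at each end, so its true width may be greater.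

Going by these compounds, how far compound 4 lies past its limit stays open. Also open, on these data alone, is whether a methyl, a methoxy, an amine or a carboxylic acid on the same carbon would bring the number back towards that of compound 2.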